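The compounds below may be only part of what the source reports. "The series", "measured", "known", "first", "only" and "open" are said of these compounds alone.

Working notes on the series. In a functional assay on HCT-8 cells (Homo sapiens) for cytotoxicity (on this read-out lower numbers stand for an effect already at smaller amounts and higher numbers for an effect only at larger amounts of compound), compound 1 `COC1=C(C)C(=O)/C(=C(O)/C=C/c2ccc(OC)cc2)C(=O)C1(C)C` gives 5.6 ug/mL, compound 2 `COC1=C(C)C(=O)/C(=C(O)/C=C/c2ccc(O)cc2)C(=O)C1(C)C` gives 14.8 ug/mL and compound 3 `CCc1ccc(/C=C/C(O)=C2/C(=O)C(C)=C(OC)C(C)(C)C2=O)cc1` gives 10.5 ug/mL. Compound 3 has the second highest of these three numbers, but it lies within the scatter of both neighbours and cannot be ranked against either.

The next compound is compound 4 `C=Cc1ccccc1/C=C/C(O)=C1/C(=O)C(C)=C(OC)C(C)(C)C1=O`, and the structural change is 2-vinylphenyl in place of 4-ethylphenyl on a double-bonded chain carbon bound to a double-bonded chain carbon. Among the measured compounds shown here, no measured step covers this exact replacement, and no measured compound carries a vinyl group or a 2-substituted phenyl. The nearest evidence comes from the three substituent swaps on the aromatic ring. The largest is a 2.6-fold higher number from compound 1 to compound 2 (0.42 log units; beyond the scatter), which is the only one beyond the scatter, and it is modest. The other two are a 1.9-fold higher number from compound 1 to compound 3 (0.27 log units; within the scatter) and a 1.4-fold lower number from compound 2 to compound 3 (0.15 log units; within the scatter). Within these three compounds, changes on the aromatic ring have therefore moved this assay only a little. The data give no basis for a direction here, so no shift beyond the scatter is expected. For the measured compounds named here, the expected step is a 1.1-fold lower number from compound 3 to compound 4 (0.02 log units; within the scatter), with wide uncertainty because the new group has no measured precedent. For compound 4 the estimated value is 10 ug/mL, with an expected range of 4 ug/mL to 25 ug/mL.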

Compound 4, concentration for half-maximal effect: 2.1 ug/mL
Compound 4: the middle estimate sits 4.8-fold (0.68 log units) above what was measured, and the stated range ends above it.
By their numbers in this assay, from the lowest: compound 4; then compounds 1, 3 and 2 (each within the scatter of the next, the first and the last beyond it).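

In this assay the aryl group on this double-bonded chain carbon matters more than the first three compounds suggested: a 5.0-fold lower number from compound 3 to compound 4 (0.70 log units; beyond the scatter), alongside a 7.0-fold lower number from compound 2 to compound 4 (0.85 log units; beyond the scatter) and a 2.7-fold lower number from compound 1 to compound 4 (0.43 log units; beyond the scatter), all beyond the scatter. Compounds 1, 2 and 3 all carry a substituent named at the 4-position of the phenyl and stay close together, whereas 2-vinylphenyl replaces 4-ethylphenyl with no change in the heavy-atom, donor or acceptor counts and still gives the lowest number of the four, so this position responds to the kind of aryl group even when those counts stay the same. No supporting measurement bears on the cause of this step.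

The change from 4-ethylphenyl to 2-vinylphenyl alters both the group and its location on the phenyl ring, and the compounds shown do not separate these two contributions. On these data alone, it also remains open whether an allyl chain, an ethynyl group or an amine in place of the vinyl group would keep the number as low as in compound 4, and whether the shared core would carry such a change equally well.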